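Swapping a Benzyl Ether for a Cyclohexyl Chain

This account rests on a few compounds, and the source may have more. Where it says the series, first, only, none or still open, it means among the compounds named here.

In a functional assay on NUGC-3 cells (Homo sapiens) for antiproliferative activity, read by sulforhodamine B assay (on this read-out higher numbers stand for weaker inhibition of growth and lower numbers for stronger inhibition of growth), compound 2 `O=C(/C=C/c1ccc(O)cc1)c1c(O)cccc1OCc1ccccc1` reaches only a limit of the assay, > 30000 nM. Compound 3 `CC(C)(C)CCOc1cccc(O)c1C(=O)CCc1ccc(O)cc1` likewise gives only a limit in this assay, > 30000 nM. Two of the three numbers therefore sit at the limit of > 30000 nM in this assay, at which 2 of the 3 values shown sit. Compound 1 `O=C(/C=C/c1ccc(O)cc1)c1c(O)cccc1OCCC1CCCC1`, in contrast, gives a measured value of 3200 nM in this assay. Compound 4 `O=C(/C=C/c1ccc(O)cc1)c1c(O)cccc1OCCC1CCCCC1` has not yet been measured. Within the data shown here, the one measured step that bears on the change it carries is an at least 9.3-fold higher number from compound 1 to compound 2 (0.97 log units; beyond the scatter), which shows that the phenyl weakened growth inhibition. Compound 4 differs from compound 2 by cyclohexylmethyl in place of phenyl on a saturated chain carbon bound to an oxygen on an aromatic ring, bringing back a saturated ring much like the cyclopentylmethyl of compound 1. A step of about an at least 10-fold lower number from compound 2 to compound 4 (1.00 log units; beyond the scatter) toward stronger inhibition is therefore expected. Compound 4 is estimated at 3000 nM, most likely between 900 nM and 12000 nM.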

Compound 4, concentration for 50% growth inhibition: > 30000 nM
Compound 4: no number, only a limit (the forecaster's own chance of this, stated with the estimate: 10%); middle value at least 10-fold (1.00 log units) away from the limit.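

Cyclohexyl in place of cyclopentyl on the same chain gives in this assay an at least 9.3-fold higher number from compound 1 to compound 4 (0.97 log units; beyond the scatter) and so shows that a saturated ring at this position does not by itself keep growth inhibition; the ring's size matters here. The step between compound 2 and compound 4 cannot be read, as both are limits. Only compound 1 now gives a number, and the others share one ceiling: the limit of > 30000 nM in this assay, at which 3 of the 4 values shown sit.

From the compounds shown here alone, whether cyclobutyl in place of cyclopentyl, or an open hexyl chain, would keep growth inhibition stays open. So does how far compound 2 and compound 4 lie past the limit.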